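Swapping an amine chain for an ester on a shared core

This account rests on a few compounds, and the source may have more. Where it says the series, first, only, none or still open, it means among the compounds named here.

Compound 1, `CN(C)CCCOc1ccc(Nc2nccc(-c3cccnc3)n2)cc1`: 600 nM
Compound 2, `NS(=O)(=O)c1ccc(Nc2nccc(-c3ccccn3)n2)cc1`: 4600 nM

Among the compounds with values here, in a functional assay for inhibition, with Homo sapiens as the target (on this read-out lower numbers stand for stronger inhibition and higher numbers for weaker inhibition), compound 1 gives 600 nM, the lowest of the two numbers measured so far. In this assay compound 2 gives 4600 nM, a gap beyond the usual scatter; as compound 2 differs from compound 1 in several places at once, no single change can be singled out as the reason.

Compound 3, `CCOC(=O)c1ccc(Nc2nccc(-c3cccnc3)n2)cc1`, has not yet been measured. It differs from compound 1 in exactly one place: ethoxycarbonyl in place of 3-(dimethylamino)propoxy on an aromatic carbon. Within the data shown here, no measured pair shows this particular change, so its size has to be guessed. Among the measured compounds shown here, the only guide is that compound 1 carries the group that leaves and gives 600 nM, the strongest inhibition seen here. For the measured compounds named here, with a change of this extent and no direct precedent, the step expected for compound 3 is a 2.5-fold higher number from compound 1 to compound 3 (0.40 log units; beyond the scatter), that is, a modest move toward weaker inhibition. Compound 3 is estimated at 1500 nM in this assay, within a range from 400 nM to 6000 nM.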

Compound 3, half-maximal inhibitory concentration: 12400 nM
Estimate against measurement, compound 3: 8.3-fold (0.92 log units) below; the whole stated range lies below it.
By their numbers in this assay, from the lowest: compound 1; then compound 2; then compound 3.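

Within the data shown here, exchanging 3-(dimethylamino)propoxy for ethoxycarbonyl on an aromatic carbon, para to a large group, gives in this assay a 21-fold higher number from compound 1 to compound 3 (1.32 log units; beyond the scatter), and this is the first step here that can be tied to a single place on the shared core. It shows that inhibition responds strongly to what this position carries, even though the two groups have the same counts of hydrogen-bond donors and acceptors, so those counts do not separate them; the clearest listed differences are that the group leaving holds a nitrogen, while the group entering holds a double bond outside the aromatic rings and no nitrogen. Nothing measured here says why the step is so large.

The exchange alters the whole chain at once, so the compounds shown leave open whether the nitrogen, the chain length or the ester carbonyl matters most. A carboxylic acid or an amide in place of the ester, or a shorter chain ending in the same dimethylamino group, would each alter fewer features and help separate these possibilities.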